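One Methyl Group Added to Compound 3

The source may hold more compounds than are shown below. What is called first, only, known or untested is meant among the compounds shown, and "the series" means these compounds.

In a functional assay on COLO 205 cells (Homo sapiens) for antiproliferative activity, read by WST assay, with a stated time of 3 days (a lower number here means a stronger inhibitor, a higher number a weaker inhibitor), compound 1 `N#Cc1cc(=O)[nH]c(=O)n1[C@@H]1O[C@H](CO)[C@@H](O)[C@H]1O` gives > 50000 nM as a limit and not a number. Compound 2 `O=c1cc(I)n([C@@H]2O[C@H](CO)[C@@H](O)[C@H]2O)c(=O)[nH]1` gives > 50000 nM as a limit too. Compound 3 `Nc1cc(=O)[nH]c(=O)n1[C@@H]1O[C@H](CO)[C@@H](O)[C@H]1O` also gives only a limit, > 50000 nM in this assay and no number. Compound 4 `CNc1cc(=O)[nH]c(=O)n1[C@@H]1O[C@H](CO)[C@@H](O)[C@H]1O` differs from compound 3 by methyl in place of hydrogen on a nitrogen on an aromatic ring with methyl in place of hydrogen on a nitrogen on an aromatic ring. The measured steps that bear on this are a step that the two limits leave unreadable from compound 1 to compound 3 and a step that the two limits leave unreadable from compound 2 to compound 3 and neither gives a size to carry over. The expected step is therefore a number no higher from compound 3 to compound 4 (the limit leaves the size open) with no shift expected beyond the scatter in either direction. Compound 4 is estimated at 50000 nM with an expected range of 25000 nM to 100000 nM in this assay.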

Compound 4, half-maximal inhibitory concentration: > 50000 nM
Compound 4 ended at the assay's limit; the forecaster's own chance of this, stated with the estimate: 85%; the middle value sits exactly at the limit.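

No step linking compound 4 to compound 1, compound 2 or compound 3 can be read, as each gives a limit of the assay and not a number: the limit of > 50000 nM in this assay, at which 4 of the 4 values shown sit.

The compounds shown leave open how strong any of them is and what the added methyl changes, if anything.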